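The source may report more compounds than this note shows. Statements on the series, on what has been measured and on what is new or still open speak of the compounds shown alone.

Measured compounds:

Compound 1, `COc1ccc(-c2cc(/C=C/C(=O)c3ccc(N)cc3)[nH]n2)cc1`, in a functional assay on NCI-H23 cells (Homo sapiens) for cytotoxicity, read by sulforhodamine B assay, with a stated time of 48 h, tested at 1 uM (a lower number here means a stronger effect, a higher number a weaker effect of the compound at the concentration tested), compound 1 gives 93%.
Compound 2, `COc1ccc(-c2cc(/C=C/C(=O)c3ccc(N)cc3)[nH]n2)cc1OC`, in this assay compound 2 gives 99%.
Compound 3, `COc1cc(C(=O)/C=C/c2cc(-c3cc(OC)c(OC)c(OC)c3)n[nH]2)cc(OC)c1OC`, in this assay compound 3 gives 97%.

Compound 2 and compound 1 differ in one place: hydrogen in place of methoxy on an aromatic carbon. The step that went with it is a number 6 percentage points lower from compound 2 to compound 1 (within the scatter), and nothing else separates the pair. Compound 3 against compound 2 shows a second core; the difference between the two cores is not broken down here, and the two values stand within the scatter of each other.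

The unmeasured compound 4, `COc1ccc(-c2cc(/C=C/C(=O)c3cc(OC)c(OC)c(OC)c3)[nH]n2)cc1OC`, differs from compound 3 by hydrogen in place of methoxy on an aromatic carbon. For the measured compounds named here, this is the same kind of change as the one from compound 2 to compound 1, not the same: around the place in compound 4 there is in addition a methoxy group meta to it. Going by the values given here, as the one measured instance of this change gave a number 6 percentage points lower from compound 2 to compound 1 (within the scatter), the step from compound 3 to compound 4 in this assay is expected to be a number 3 percentage points lower from compound 3 to compound 4 (within the scatter). Starting from the value of compound 3, compound 4 is estimated at 94% in this assay, expected to lie between 84% and 102%.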

Compound 4, a percentage reported as activity, at one concentration (the size of the read-out at that concentration, not a potency): 87%
Beside the measured number, compound 4's estimate is 7 percentage points above it; the measured number falls inside the stated range.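

Hydrogen in place of methoxy on an aromatic carbon goes with a number 10 percentage points lower from compound 3 to compound 4 (within the scatter) in this assay. Set beside the earlier instance of the change, this step does not differ from it, so nothing here separates the two cores for this change: the same change on two cores in this assay, a number 6 percentage points lower (within the scatter) from compound 2 to compound 1 and a number 10 percentage points lower (within the scatter) from compound 3 to compound 4, 4 percentage points apart, within the scatter of two such steps. As both steps lie within the scatter, the two instances agree without showing that the change has a real effect on either core, and two pairs at a single concentration give no measure of potency and no rule for a further core.

The compounds shown carry only hydrogen or methoxy at the place of this change, so it remains open whether a longer chain such as ethoxy, a halogen such as fluorine or a carboxylic acid there would move the read-out beyond the scatter. Also open is whether the two cores would still match at higher concentrations, where the read-out of these compounds may lie further from the values seen here.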